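The source may report more compounds than this note shows. Statements on the series, on what has been measured and on what is new or still open speak of the compounds shown alone.

Compound 1 `CC(C)CCn1cnc2c(NCc3cccc(Cl)c3)nc(N[C@H]3CC[C@H](N)CC3)nc21`: 16700 nM
Compound 2 `COc1cc(Nc2nc(N[C@H]3CC[C@H](N)CC3)nc3c2ncn3CCC(C)C)cc(OC)c1`: 11200 nM
Compound 3 `CC(C)CCn1cnc2c(Nc3cccc(O)c3)nc(N[C@H]3CC[C@H](N)CC3)nc21`: 21300 nM

These values come from a functional assay on HCC827 cells (Homo sapiens) for inhibition, read by fluorescence, with a stated time of 72 h; on this read-out lower numbers stand for stronger inhibition of growth and higher numbers for weaker inhibition of growth. Compound 3, at 21300 nM, lies within the scatter of both other compounds. Compound 4 `CC(C)CCn1cnc2c(Nc3ccc(O)cc3)nc(N[C@H]3CC[C@H](N)CC3)nc21` has the same atoms as compound 3, joined differently: 4-hydroxyphenyl in place of 3-hydroxyphenyl on a nitrogen on an aromatic ring. The measured steps that bear on this change were made on the same nitrogen. They are a 1.3-fold higher number from compound 1 to compound 3 (0.11 log units; within the scatter), a 1.9-fold higher number from compound 2 to compound 3 (0.28 log units; within the scatter) and a 1.5-fold lower number from compound 1 to compound 2 (0.17 log units; within the scatter). None goes beyond the scatter, although each exchanges two different groups, not just two placements of one group. In this assay the expected result is therefore a 1.2-fold lower number from compound 3 to compound 4 (0.07 log units; within the scatter), with no step beyond the scatter. Compound 4 is estimated at 18000 nM, with an expected range of 8000 nM to 40000 nM.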

Compound 4, concentration for 50% growth inhibition: 14400 nM
The estimate for compound 4 lay 1.3-fold (0.10 log units) above the measured number; low and high end bracket the measured number.
By their numbers in this assay, from the lowest: compounds 2, 4, 1 and 3 (each within the scatter of the next).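

Exchanging 3-hydroxyphenyl for 4-hydroxyphenyl on this nitrogen, which only relocates one group, gives in this assay (a 1.5-fold lower number from compound 3 to compound 4 (0.17 log units; within the scatter)). The exchanges of different groups for 4-hydroxyphenyl also stay small (a 1.3-fold higher number from compound 2 to compound 4 (0.11 log units; within the scatter); a 1.2-fold lower number from compound 1 to compound 4 (0.06 log units; within the scatter)), so none of the four compounds can be told apart at this position. Nothing available explains these numbers.

Going by these compounds, whether a carboxylic acid on the phenyl ring or a longer chain carrying an amine on this nitrogen would give a step beyond the scatter remains open. So does whether this relocation would matter in a compound with stronger growth inhibition.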